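3,5-Dimethoxyphenyl to 3-chlorophenyl on the butyl compound

The compounds below may be only part of what the source reports. "The series", "measured", "known", "first", "only" and "open" are said of these compounds alone.

In a functional assay on BT-474 cells (Homo sapiens) for inhibition, read by fluorescence, with a stated time of 72 h (on this read-out lower numbers stand for stronger inhibition of growth and higher numbers for weaker inhibition of growth), compound 3 (`CCCCn1cnc2c(Nc3cc(OC)cc(OC)c3)nc(N[C@H]3CC[C@H](N)CC3)nc21`) gives 15600 nM. This lies within the scatter of compound 1 (`COc1ccc(Cn2cnc3c(Nc4cccc(Cl)c4)nc(N[C@H]4CC[C@H](N)CC4)nc32)cc1`) at 8200 nM, and is a higher number, beyond the scatter, than compound 2 (`CC(C)=CCn1cnc2c(Nc3cccc(Cl)c3)nc(N[C@H]3CC[C@H](N)CC3)nc21`) at 7000 nM. Compound 4 (`CCCCn1cnc2c(Nc3cccc(Cl)c3)nc(N[C@H]3CC[C@H](N)CC3)nc21`) has 3-chlorophenyl in place of 3,5-dimethoxyphenyl on a nitrogen on an aromatic ring. Going by the values given here, no measured step changes this group directly. Among the compounds with values here, the only measured step, a 1.2-fold lower number from compound 1 to compound 2 (0.07 log units; within the scatter), changes another group, stays within the scatter, and joins two compounds that both carry 3-chlorophenyl. A step toward a lower number, a 2.1-fold lower number from compound 3 to compound 4 (0.32 log units; beyond the scatter), is therefore expected in this assay. For compound 4 the estimate is 7500 nM, with an expected range of 3500 nM to 15000 nM.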

Compound 4, concentration for 50% growth inhibition: 5100 nM
Compound 4: middle estimate off by 1.5-fold (0.17 log units), on the high side; low and high end bracket the measured number.
By their numbers in this assay, from the lowest: compounds 4, 2, 1 and 3 (each within the scatter of the next, the first and the last beyond it).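

In this assay, the group on a nitrogen on an aromatic ring now has a measured effect with the butyl group held: a 3.1-fold lower number from compound 3 to compound 4 (0.49 log units; beyond the scatter) is beyond the scatter. With 3-chlorophenyl held, the chain-end changes stay small, with a 1.4-fold lower number from compound 2 to compound 4 (0.14 log units; within the scatter) for 2-methylprop-1-en-1-yl to propyl and a 1.6-fold lower number from compound 1 to compound 4 (0.21 log units; within the scatter) for 4-methoxyphenyl to propyl. No evidence here accounts for these steps. Open, from the compounds shown here alone, is how a fluorophenyl or pyridine ring would compare on that nitrogen, and whether the step from 3,5-dimethoxyphenyl to 3-chlorophenyl carries over to compounds with other groups on the chain.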